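Swapping the Pyrimidine Ring of Compound 1 for Thiophene

This account rests on a few compounds, and the source may have more. Where it says the series, first, only, none or still open, it means among the compounds named here.

Measured compounds:
compound 1 `Cc1cc(O)nc(C[S+]([O-])C(c2ccccc2)c2ccccc2)n1`: 109000 nM
compound 2 `Cc1cnc(C[S+]([O-])C(c2ccccc2)c2ccccc2)nc1`: 156000 nM
compound 3 `[O-][S+](Cc1ccsc1Br)C(c1ccccc1)c1ccccc1`: 29300 nM

All three share a core in which a sulfur-bearing chain carbon carries a ring. In an assay on HEK293 cells for inhibition of sodium-dependent dopamine transporter (Homo sapiens), read by scintillation counting, with stated times of 5 min and 1 min (on this read-out lower numbers stand for stronger inhibition and higher numbers for weaker inhibition), compound 1 stands second highest of the three numbers; its nearest neighbour is compound 2, with a 1.4-fold higher number from compound 1 to compound 2 (0.16 log units; within the scatter), and the furthest is compound 3, with a 3.7-fold lower number from compound 1 to compound 3 (0.57 log units; beyond the scatter). The step of a 5.3-fold lower number from compound 2 to compound 3 (0.73 log units; beyond the scatter) points the same way.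

Compound 4 `[O-][S+](Cc1ccsc1)C(c1ccccc1)c1ccccc1` differs from compound 1 as follows: thiophen-3-yl in place of 4-hydroxy-6-methylpyrimidin-2-yl on a saturated chain carbon bound to a sulfur. The step from compound 1 to compound 3 bears most directly on this change, since compound 3 also replaces the pyrimidine by a thiophene, though a brominated one, and that step was modest but beyond the scatter. The step from compound 1 to compound 2 shows that removing the hydroxyl alone stays within the scatter. Compound 4 is therefore expected to land between compound 1 and compound 3, a modest lowering of the number of a 2.2-fold lower number from compound 1 to compound 4 (0.34 log units; beyond the scatter). On that basis compound 4 is estimated at 50000 nM, with a likely range from 20000 nM to 130000 nM.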

Compound 4, half-maximal inhibitory concentration: 3000 nM
For compound 4 the middle estimate is 17-fold (1.22 log units) above the measured one; measured number outside the range, below it.
By their numbers in this assay, from the lowest: compound 4; then compound 3; then compounds 1 and 2 (each within the scatter of the next).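

In this assay, the plain thiophen-3-yl group on a saturated chain carbon bound to a sulfur brings a far larger change than the brominated thiophene had suggested: the replacement of the pyrimidine rings gives a 36-fold lower number from compound 1 to compound 4 (1.56 log units; beyond the scatter) and a 52-fold lower number from compound 2 to compound 4 (1.72 log units; beyond the scatter) and both steps are large, while those to compound 3 were only modest. The bromo group therefore did not contribute to the stronger inhibition seen with compound 3, since hydrogen in place of bromo on an aromatic carbon gives a 9.8-fold lower number from compound 3 to compound 4 (0.99 log units; beyond the scatter) and shows that compound 3 had hidden much of what the thiophene swap can deliver. The data shown offer no measurement that would explain the size of these steps.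

As far as these compounds go, whether the gain depends on the thiophene itself stays open, as a phenyl, a furan-3-yl or a thiophen-2-yl group in the same place would be needed to tell. From the compounds shown here alone, it also remains open whether the loss seen with bromo extends to a chloro or a methyl group in its place on the thiophene ring.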